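A few compounds are considered here, and "the series" means these few. Any claim that something is new, unique, unknown or untested is made for them only; others in the source may bear on it.

Going by the values given here, in an assay on isolated protein for inhibition of retinal dehydrogenase 2 (Homo sapiens) (a higher number here means a weaker inhibitor, a lower number a stronger inhibitor), compound 2 `CC(Sc1nc2c(cnn2C)c(=O)n1-c1ccccc1)c1cccc(F)c1` gives 110 nM, the lowest of the three numbers measured so far, which makes compound 2 the strongest inhibitor in this small set. Compound 1 `Cn1ncc2c(=O)n(-c3ccccc3)c(SC(C)(C)c3ccccc3)nc21` gives 2200 nM, and compound 3 `Cn1ncc2c(=O)n(-c3ccccc3)c(CNc3cccc(F)c3)nc21` gives 2300 nM. Compound 4 `CC(Sc1nc2c(cnn2C)c(=O)n1-c1ccccc1)c1ccccc1` differs from compound 2 only by hydrogen in place of fluoro on an aromatic carbon. Among the compounds with values here, the single measured step that touches this part of the molecule, a 20-fold lower number from compound 1 to compound 2 (1.30 log units; beyond the scatter), swapped the whole group on the sulfur at once, so it does not separate the contribution of the fluoro from the rest of that group. Within the data shown here, no measured step isolates the loss of a fluoro alone. The step of a 1.6-fold higher number from compound 2 to compound 4 (0.21 log units; within the scatter) is therefore expected to stay within the scatter, leaning only slightly toward a higher number. Compound 4 is estimated at 180 nM, between 70 nM and 500 nM.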

Compound 4, half-maximal inhibitory concentration: 110 nM
Compound 4: the middle estimate sits 1.6-fold (0.21 log units) above what was measured; low and high end bracket the measured number.
By their numbers in this assay, from the lowest: compounds 2 and 4 (each within the scatter of the next); then compounds 1 and 3 (each within the scatter of the next).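

In this assay hydrogen in place of fluoro gives no change at the digits printed from compound 2 to compound 4 (within the scatter) and so this fluoro is not needed to keep the number of compound 2. Hydrogen in place of methyl on the saturated chain carbon bound to the sulfur gives a 20-fold lower number from compound 1 to compound 4 (1.30 log units; beyond the scatter) and so that single methyl, with no fluoro involved, is enough to produce a large step. No evidence here explains either result.

Going by these compounds, whether a methoxy group or a carboxylic acid would be tolerated on the same aromatic ring remains open. So does the effect of a longer chain in place of the remaining methyl.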